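Adding Trifluoromethoxy to Compound 1: A Growth Inhibition Estimate

The compounds below may be only part of what the source reports. "The series", "measured", "known", "first", "only" and "open" are said of these compounds alone.

Measured so far in a functional assay on A549 cells (Homo sapiens) for inhibition, read by sulforhodamine B assay; a lower number here means a stronger inhibitor of growth, a higher number a weaker inhibitor of growth:
- Compound 1 `c1ccc(-c2ccc(-c3ccc(-c4nc5ccccc5[nH]4)cc3)cc2)cc1`: 41200 nM
- Compound 2 `Cc1ccc2[nH]c(-c3ccc(-c4ccc(-c5cccc(Cl)c5)cc4)cc3)nc2c1`: 2800 nM
- Compound 3 `COc1cc(-c2ccc(-c3ccc(-c4nc5cc(C)ccc5[nH]4)cc3)cc2)cc(OC)c1OC`: < 100 nM (a limit of the assay)

Among the actual numbers in this assay, compound 1 stands highest at 41200 nM. The nearest number is that of compound 2 at 2800 nM, lower by more than the usual scatter. For compound 3, the result of < 100 nM is a limit and not a number.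

Compound 4 `FC(F)(F)Oc1ccc(-c2ccc(-c3ccc(-c4nc5ccccc5[nH]4)cc3)cc2)cc1` has not yet been measured. It differs from compound 1 by trifluoromethoxy in place of hydrogen on an aromatic carbon of a six-membered aromatic ring of carbon only, para to a large group (trifluoromethoxy in place of hydrogen on an aromatic carbon).

Within the data shown here, no two measured compounds differ in one place only, so the comparison is loose. Compound 2, at 2800 nM, carries added groups on the core of compound 1 and has the lower number, which points to a lower number for compound 4 as well. The change a 6.9-fold lower number from compound 1 to compound 4 (0.84 log units; beyond the scatter) is expected to lie beyond the scatter, toward stronger inhibition of growth. For compound 4 the estimated value is 6000 nM, with an expected range from 1200 nM to 25000 nM.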

Compound 4, concentration for 50% growth inhibition: 38000 nM
Estimate against measurement, compound 4: 6.3-fold (0.80 log units) below; measured number above the stated range.
By their numbers in this assay, from the lowest: compound 2; then compounds 4 and 1 (each within the scatter of the next). At a limit, below all of these: compound 3.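

In this assay, trifluoromethoxy in place of hydrogen on an aromatic carbon of the six-membered aromatic ring of carbon only, para to a large group, gives a 1.1-fold lower number from compound 1 to compound 4 (0.04 log units; within the scatter) and so leaves the two numbers within the scatter of each other. Among these compounds, this is the first step in the set that differs in one place only, and it shows that at this position a group of 5 heavy atoms, with no ring and 1 hydrogen-bond acceptor, can replace hydrogen with no readable difference in this read-out. Nothing measured here bears on why the two numbers cannot be told apart.

From the compounds shown here alone, whether the same holds at this position for another group, such as an amine or a carboxylic acid, stays open, as does the outcome for trifluoromethoxy placed elsewhere on the core of compound 1. Compound 2 and compound 3 each differ from compound 1 in more than one place, so the compounds shown cannot say which of their groups goes with their values.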